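Aryl tetrazole acetamides on Kir3.1/Kir3.2: compound 3 outlook

A few compounds are considered here, and "the series" means these few. Any claim that something is new, unique, unknown or untested is made for them only; others in the source may bear on it.

Of the compounds shown here, two have been tested, and only one of them has a number. Compound 1 `O=C(Cn1nnc(-c2ccccc2)n1)Nc1ccccn1` is reported in an assay on HEK293 cells for activation of Kir3.1/Kir3.2 (Homo sapiens), read by thallium flux (on this read-out lower numbers stand for an effect already at smaller amounts and higher numbers for an effect only at larger amounts of compound), as "not active" (no number reported), so it gives no value to compare against. Among the compounds with values here, compound 2 `Cc1cc(NC(=O)Cn2nnc(-c3ccccc3F)n2)n(C2CCCCC2)n1` in this assay gives 187 nM, the sole number in the set; compound 2 therefore stands alone, with no second measured value to place it above or below.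

Compound 3 `Cc1cc(NC(=O)Cn2nnc(-c3cccc(C(F)(F)F)c3)n2)n(C2CCCCC2)n1` is the next entry to be measured. It differs from compound 2 in one place: 3-(trifluoromethyl)phenyl in place of 2-fluorophenyl on an aromatic carbon. Within the data shown here, no measured pair isolates this exchange, so there is no step to lean on. With a single number in hand, the expectation for compound 3 is a step in this assay of a 1.6-fold higher number from compound 2 to compound 3 (0.21 log units; within the scatter), which is taken to be no larger than the usual scatter, with a slight lean toward the higher side. On that basis compound 3 is estimated at 300 nM in this assay, with a range from 80 nM to 1500 nM.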

Compound 3, half-maximal effective concentration: 183 nM
The estimate for compound 3 lay 1.6-fold (0.21 log units) above the measured number; measured number inside the range.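

In this assay, 3-(trifluoromethyl)phenyl in place of 2-fluorophenyl on the aromatic carbon of the ring with 4 nitrogen gives a 1.0-fold lower number from compound 2 to compound 3 (0.01 log units; within the scatter), so the two numbers cannot be told apart. Within the data shown here, this is the first measured step at this position, and it shows that an aryl group of 10 heavy atoms with three fluorine atoms and one of 7 heavy atoms with a single fluorine both give numbers in the same range on the shared core, where earlier only one number stood without a comparison. The exchange alters both the substituent and its place on the phenyl ring at once, and no independent data bear on the reason for this result.

Open, on these data alone, is whether the two alterations have separate effects that happen to cancel or whether neither matters here, a question that 3-fluorophenyl or 2-(trifluoromethyl)phenyl on the same carbon would address. Also open, as far as these compounds go, is how far this range extends to a phenyl ring carrying an amine or a carboxylic acid, or to a saturated ring or a longer alkyl chain at this position.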